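Swapping Phenyl for Amino on a Squalene Synthase Inhibitor

The source may hold more compounds than are shown below. What is called first, only, known or untested is meant among the compounds shown, and "the series" means these compounds.

Compound 1 `CC(C)NCCCOc1ccc(-c2ccccc2)cc1`: 170 nM
Compound 2 `C=CCc1cc(OCCCC)ccc1OCCCNC(C)C`: 0.6 nM
Compound 3 `C=CCc1cc(-c2ccccc2)ccc1OCCCNC(C)C`: 0.004 nM

In an assay for inhibition of squalene synthase (Rattus norvegicus), using microsomes (a higher number here means a weaker inhibitor, a lower number a stronger inhibitor), compound 3 gives the lowest number of the three, with compound 2 nearest and compound 1 furthest. Compound 4 `C=CCc1cc(N)ccc1OCCCNC(C)C` differs from compound 3 in one place: amino in place of phenyl on an aromatic carbon. Within the data shown here, two measured steps bear on this change. The step of a 150-fold lower number from compound 2 to compound 3 (2.18 log units; beyond the scatter) shows how much the phenyl group adds over butoxy, and a 43000-fold lower number from compound 1 to compound 3 (4.63 log units; beyond the scatter) shows that each group of compound 3 carries a large share of its potency. Amino is a far smaller group than either phenyl or butoxy, so a large rise in the number is expected, estimated as the step of a 25000-fold higher number from compound 3 to compound 4 (4.40 log units; beyond the scatter). Compound 4 is therefore expected to give 100 nM, within 5 nM to 2000 nM.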

Compound 4, half-maximal inhibitory concentration: 250 nM
Compound 4: the middle estimate sits 2.5-fold (0.40 log units) below what was measured; the measured number falls inside the stated range.
By their numbers in this assay, from the lowest: compound 3; then compound 2; then compounds 1 and 4 (each within the scatter of the next).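

Among these compounds, at this place on the ring, para to a group of 8 heavy atoms, the choice of group matters even more than the earlier compounds showed: in this assay amino gives a 63000-fold higher number from compound 3 to compound 4 (4.80 log units; beyond the scatter) and also a 420-fold higher number from compound 2 to compound 4 (2.62 log units; beyond the scatter) when set against butoxy. The three groups at this place therefore stand in a clear order, with phenyl lowest, then butoxy, then amino. Nothing measured here gives a reason for this order. On these data alone, whether a methyl or a hydroxyl group would stay as high as amino remains open, as does whether a pyridine ring could match phenyl.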